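A few compounds are considered here, and "the series" means these few. Any claim that something is new, unique, unknown or untested is made for them only; others in the source may bear on it.

Measured so far in an ADME assay on BJ cells (Homo sapiens) for cytotoxicity, with a stated time of 72 h; a higher number here means that more compound is needed for the effect, a lower number that less compound is needed:
- Compound 1 `COc1cccc(-c2nc3c(c(C)nn3-c3ccccc3)c(-c3ccccc3O)c2C#N)c1`: > 23000 nM (a limit)
- Compound 2 `Cc1nn(-c2ccccc2)c2nc(-c3ccccc3)c(C#N)c(-c3ccccc3O)c12`: > 23000 nM (a limit)

Compound 2 is known only as a limit, > 23000 nM. Among the compounds with values here, the whole series so far rests on (the limit of > 23000 nM in this assay, at which 2 of the 2 values shown sit), so no number is yet available for either compound.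

Compound 3 `Cc1nn(-c2ccccc2)c2nc(-c3ccc(C(C)C)cc3)c(C#N)c(-c3ccccc3O)c12` differs from compound 2 by one change: isopropyl in place of hydrogen on an aromatic carbon, which is phenyl to 4-isopropylphenyl.

Within the data shown here, the only measured step is a step that the two limits leave unreadable from compound 1 to compound 2, with hydrogen in place of methoxy on an aromatic carbon. It offers no size to carry over to the new change, so no shift beyond the scatter is expected in this assay, and another limit is the likeliest report. The expected change is an at least 1.1-fold lower number from compound 2 to compound 3 (0.06 log units; that floor lies within the scatter). Compound 3 is estimated at 20000 nM, with an expected range of 9000 nM to 30000 nM.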

Compound 3, half-maximal effective concentration: 22600 nM
Estimate against measurement, compound 3: 1.1-fold (0.05 log units) below; low and high end bracket the measured number.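

In this assay the 4-isopropylphenyl group gives the series its first number that is not a limit, yet the step reads only as an at least 1.0-fold lower number from compound 2 to compound 3 (0.00 log units; that floor lies within the scatter) and no more. As an at least 1.0-fold lower number from compound 1 to compound 3 (0.00 log units; that floor lies within the scatter) the exchange of the whole aromatic substituent reads no differently. Both floors lie within the scatter, so isopropyl at this place, para to a large group, shows no shift that can be claimed, and the true size of either step cannot be read because the partner values are limits: the limit of > 23000 nM in this assay, at which 2 of the 3 values shown sit.

Open, going by these compounds, is whether another group at this place, such as an amine, a carboxylic acid or a longer chain, would bring the number clearly lower. With a single value that is not a limit, no trend in the series can be stated.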